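The source may hold more compounds than are shown below. What is called first, only, known or untested is meant among the compounds shown, and "the series" means these compounds.

In a functional assay on HUVEC cells (Homo sapiens) (a lower number here means that less compound is needed, a higher number that more compound is needed for the effect), compound 3 `CCC1=C(OC)C(CC)(CC)C(=O)C(C(=O)/C=C/c2ccccc2)=C1O` gives only a limit, < 4 ug/mL. Compound 1 `COC1=C(C)C(=O)/C(=C(O)/C=C/c2ccc(C)cc2)C(=O)C1(C)C` also gives a limit, < 4 ug/mL. Compound 2 `C=Cc1ccccc1/C=C/C(O)=C1/C(=O)C(C)=C(OC)C(C)(C)C1=O` likewise gives a limit, < 1.1 ug/mL. No exact number is therefore available anywhere in the series. Compound 4 `CCC1=C(OC)C(CC)(CC)C(=O)C(C(=O)/C=C/c2ccc(CC)cc2)=C1O` differs from compound 3 by ethyl in place of hydrogen on an aromatic carbon, the change from phenyl to 4-ethylphenyl. Within the data shown here, the one measured step that bears on this change, a step that the two limits leave unreadable from compound 1 to compound 2, also alters a substituent on the aromatic ring but has no readable size. With no size to carry over, no shift beyond the scatter is expected in this assay. The expected step is a step that the limit leaves unreadable from compound 3 to compound 4. For compound 4 the estimated value is 2 ug/mL, with an expected range from 0.7 ug/mL to 5 ug/mL.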

Compound 4, concentration for half-maximal effect: < 4 ug/mL
Compound 4 ended at the assay's limit; the forecaster's own chance of this, stated with the estimate: 70%; the middle value does not contradict the limit.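

In this assay compound 3 and compound 4 both give only limits, and no step can be read between them. The compounds shown leave open whether ethyl in place of hydrogen on the aromatic carbon shifts the value at all.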